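Solubility at low pH: swapping a chain-end piperidine for an acetylpiperidine

The source may hold more compounds than are shown below. What is called first, only, known or untested is meant among the compounds shown, and "the series" means these compounds.

Compound 1 `NC(=O)c1ccc2[nH]c(-c3ccc(OCCCN4CCCCC4)cc3)nc2c1` carries a 3-(piperidin-1-yl)propyl group on an oxygen of its shared core. In a physicochemical assay for solubility, with a stated time of 3 days, at pH 2 (on this read-out lower numbers stand for lower solubility and higher numbers for higher solubility), compound 1 reaches only the limit of the measurement, > 400000 nM, so its true solubility is not known as a number. Compound 3 `CN1CCC(Oc2ccc(-c3nc4cc(C(N)=O)ccc4[nH]3)cc2)CC1` likewise stops at the limit, > 400000 nM. For compound 2 `NC(=O)c1ccc2[nH]c(-c3ccc(OC4CCNCC4)cc3)nc2c1` the result is "not determined" (no result reported). Within the data shown here, the one comparable step, a step that the two limits leave unreadable from compound 1 to compound 3, therefore cannot be sized, and the only evidence is the limit of > 400000 nM in this assay, at which 2 of the 3 values shown sit.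

Compound 4 `CC(=O)N1CCCCC1CCOc1ccc(-c2nc3cc(C(N)=O)ccc3[nH]2)cc1` differs from compound 1 by 1-acetylpiperidin-2-yl in place of (piperidin-1-yl)methyl on a saturated chain carbon, two bonds along the chain from an oxygen on an aromatic ring. Among the measured compounds shown here, no measured step covers this change, and the measured steps say nothing about its size or direction. The step is expected to be a fall in solubility, an at least 4.0-fold lower number from compound 1 to compound 4 (0.60 log units; beyond the scatter), though its size rests on judgement alone. Compound 4 is thus expected to give about 100000 nM in this assay, with a range from 20000 nM to 400000 nM, and a fair chance that only a limit is again reported.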

Compound 4, solubility: > 400000 nM
Compound 4: a limit, no number; the forecaster's own chance of this, stated with the estimate: 35%; at least 4.0-fold (0.60 log units) between middle value and limit.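

Compound 1 and compound 4 both give only a limit in this assay, so no step between them can be read: the limit of > 400000 nM in this assay, at which 3 of the 4 values shown sit.

The compounds shown leave open how soluble each truly is, and whether the change from compound 1 to compound 4 moves the number at all.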